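A few compounds are considered here, and "the series" means these few. Any claim that something is new, unique, unknown or untested is made for them only; others in the source may bear on it.

Among the compounds with values here, in a functional assay on MCF7 cells (Homo sapiens) for cytotoxicity, read by MTT assay, with a stated time of 72 h (a lower number here means a stronger inhibitor, a higher number a weaker inhibitor), three compounds sharing one core have numbers so far. Compound 1 `COc1cccc(/C=C2\CCC/C(=C\c3ccc(Br)cc3)C2=O)c1OC` gives 13800 nM, compound 2 `COc1ccccc1/C=C1\CCC/C(=C\c2cccc(OC)c2OC)C1=O` gives 12000 nM, and compound 3 `COc1cccc(/C=C2\CCC/C(=C\c3cccc(O)c3)C2=O)c1OC` gives 8800 nM. Compound 3 stands level with the other two, as its steps to them, a 1.6-fold lower number from compound 1 to compound 3 (0.20 log units; within the scatter) and a 1.4-fold lower number from compound 2 to compound 3 (0.13 log units; within the scatter), both lie within the usual scatter of repeated measurements.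

The next compound, compound 4 `COc1cccc(/C=C2\CCC/C(=C\c3ccc(Cl)c(Cl)c3)C2=O)c1OC`, keeps the core and changes one group: 3,4-dichlorophenyl in place of 3-hydroxyphenyl on a double-bonded chain carbon bound to a double-bonded ring carbon. Here 3,4-dichlorophenyl takes the place of 3-hydroxyphenyl on a double-bonded chain carbon bound to a double-bonded ring carbon.

All three measured steps exchange a group at this same place, and the remaining one, a 1.2-fold lower number from compound 1 to compound 2 (0.06 log units; within the scatter), also stays within the scatter. The closest guide is compound 1, which carries a halogen on its ring in the form of 4-bromophenyl and gives 13800 nM. So far, then, exchanges at this place have not moved the number measurably, although no compound yet carries two chlorines. No step beyond the scatter is expected in this assay, and the data favour no clear direction. The estimated step is small: a 1.3-fold higher number from compound 3 to compound 4 (0.10 log units; within the scatter). The expected value for compound 4 is 11000 nM, with an estimated range from 5000 nM to 24000 nM.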

Compound 4, half-maximal inhibitory concentration: 9000 nM
Estimate against measurement, compound 4: 1.2-fold (0.09 log units) above; the measured number falls inside the stated range.
By their numbers in this assay, from the lowest: compounds 3, 4, 2 and 1 (each within the scatter of the next).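

Within this assay, the exchange of 3-hydroxyphenyl for 3,4-dichlorophenyl on a double-bonded chain carbon bound to a double-bonded ring carbon gives a 1.0-fold higher number from compound 3 to compound 4 (0.01 log units; within the scatter) even though the entering group has no hydrogen-bond donor or acceptor and carries two chlorine atoms, so a substantial change in the group's make-up leaves the reading level with that of compound 3. The same group also stands level with the other two groups at this place, with a 1.3-fold lower number from compound 2 to compound 4 (0.12 log units; within the scatter) and a 1.5-fold lower number from compound 1 to compound 4 (0.19 log units; within the scatter) as its steps, which extends the flat picture at this position to a ring with two chlorines and means that all four compounds lie within the scatter of one another. No evidence on hand speaks to why these exchanges leave the number level.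

Every group shown at this place is a substituted phenyl ring, so it stays open whether a phenyl ring bearing an amine or a carboxylic acid, or a longer chain, would give a step beyond the scatter. On these data alone, it is equally open whether changes elsewhere on the shared core would move the number in this assay more than these exchanges have.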